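The source may hold more compounds than are shown below. What is called first, only, known or untested is meant among the compounds shown, and "the series" means these compounds.

Measured in an ADME assay on CCRF-HSB-2 cells (Homo sapiens) for cytotoxicity, with a stated time of 7 days; on this read-out lower numbers stand for higher toxicity in this test and higher numbers for lower toxicity in this test:
- compound 1 `CNc1nc(N)nc2c1ncn2/C=C1/CC1(CO)CO`: > 20000 nM, a limit
- compound 2 `CCCSc1nc(N)nc2c1ncn2/C=C1/CC1(CO)CO`: 98000 nM
- compound 3 `Nc1nc(SC2CCCC2)c2ncn(/C=C3/CC3(CO)CO)c2n1`: 91000 nM

For the measured compounds named here, compound 3 stands level with the only other number. Compound 4 `CCCCNc1nc(N)nc2c1ncn2/C=C1/CC1(CO)CO` carries butylamino in place of cyclopentylsulfanyl on an aromatic carbon. The steps between methylamino and the sulfanyl groups bear most directly, but a step that the limit leaves unreadable from compound 1 to compound 2 and a step that the limit leaves unreadable from compound 1 to compound 3 give no usable size. Going by the values given here, the one readable step, a 1.1-fold lower number from compound 2 to compound 3 (0.03 log units; within the scatter), changes only the group on sulfur. No step beyond the scatter is therefore expected in this assay, and the expected change is a 1.3-fold lower number from compound 3 to compound 4 (0.11 log units; within the scatter). For compound 4 the estimate is 70000 nM, with an expected range of 20000 nM to 200000 nM.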

Compound 4, half-maximal cytotoxic concentration: > 20000 nM
Compound 4 gave a limit, no number; the forecaster's own chance of this, stated with the estimate: 55%; the middle value does not contradict the limit.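

Compound 4 gives only a limit, as does compound 1, so no step among compound 4, compound 1, compound 2 and compound 3 can be newly read in this assay: the limit of > 20000 nM in this assay, at which 2 of the 4 values shown sit.

Open remains how methylamino in compound 1 and butylamino in compound 4 stand against the sulfanyl groups of compound 2 and compound 3 in this assay.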